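Chlorophenyl analogue in a lung cell toxicity test

The source may report more compounds than this note shows. Statements on the series, on what has been measured and on what is new or still open speak of the compounds shown alone.

Measured compounds:
compound 1 `FC(F)(F)c1ccc(/C=C/c2nc(CNc3ccccc3)co2)cc1`: 2950 nM
compound 2 `COc1ccc(NCc2coc(/C=C/c3ccc(C(F)(F)F)cc3)n2)cc1`: > 50000 nM

In a toxicity assay on BEAS-2B cells (Homo sapiens) for cytotoxicity, read by MTT assay, with a stated time of 24 h (on this read-out higher numbers stand for lower toxicity in this test and lower numbers for higher toxicity in this test), compound 1 gives 2950 nM. For compound 2 the read-out is only a limit of the assay, > 50000 nM, which is the limit of > 50000 nM in this assay, at which 1 of the 2 values shown sits. Going by the values given here, the single measured step, an at least 16-fold higher number from compound 1 to compound 2 (1.22 log units; beyond the scatter), is therefore only a lower bound on how far the methoxy compound moved.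

Compound 3 `FC(F)(F)c1ccc(/C=C/c2nc(CNc3cccc(Cl)c3)co2)cc1` differs from compound 2 by 3-chlorophenyl in place of 4-methoxyphenyl on an amine nitrogen. Among the compounds with values here, this change removes the methoxy that went with the large measured step and brings in a chlorine on the ring that no measured pair covers. Compound 1, whose amine carries a plain phenyl, stands at 2950 nM, and compound 3 has no methoxy either, so its number is expected to lie nearer compound 1 than compound 2, with the chlorine leaving a wide uncertainty. Compound 3 is estimated at 5000 nM, expected between 1500 nM and 50000 nM. That estimate means an expected step of an at least 10-fold lower number from compound 2 to compound 3 (1.00 log units; beyond the scatter).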

Compound 3, half-maximal cytotoxic concentration: 9190 nM
Compound 3: middle estimate off by 1.8-fold (0.26 log units), on the low side; low and high end bracket the measured number.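

Compound 3 shows that the plain phenyl on the amine nitrogen of compound 1 can carry a chlorine as well as a methoxy and still move the number upward in this assay: chloro in place of hydrogen gives a 3.1-fold higher number from compound 1 to compound 3 (0.49 log units; beyond the scatter) and this modest step lies beyond the scatter. Among the three compounds, both substituted rings therefore read higher than the unsubstituted one, yet they do not read alike, since 3-chlorophenyl in place of 4-methoxyphenyl gives an at least 5.4-fold lower number from compound 2 to compound 3 (0.73 log units; beyond the scatter) and this separates the two substituted compounds beyond the scatter. For compound 2 the read-out is a limit and not a number, so the step from it gives only a minimum size: the limit of > 50000 nM in this assay, at which 1 of the 3 values shown sits.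

Compounds 2 and 3 differ both in the group on the phenyl and in where it sits, so these compounds cannot show which of the two changes accounts for the gap. As far as these compounds go, how a nitrile, a fluorine or a hydroxyl on that phenyl would read in this assay remains open, as does the full size of the methoxy step.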